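From Iodo to Methyl on the Amide Aryl Ring

The source may report more compounds than this note shows. Statements on the series, on what has been measured and on what is new or still open speak of the compounds shown alone.

Compound 1 `CCC(=O)Nc1c(C(O)(C(F)(F)F)C(F)(F)F)ccc2ccccc12` and compound 2 `O=C(Nc1c(C(O)(C(F)(F)F)C(F)(F)F)ccc2ccccc12)c1ccc(I)cc1` share one core and differ only in the group on the carbonyl carbon of the amide. In an assay on LtK cells with ATP-sensitive inward rectifier potassium channel 11 (Homo sapiens) as the target (on this read-out lower numbers stand for an effect already at smaller amounts and higher numbers for an effect only at larger amounts of compound), compound 1 gives 15 nM, and compound 2 gives 154 nM. The step of a 10-fold higher number from compound 1 to compound 2 (1.01 log units; beyond the scatter) is the only one measured, and on these two numbers compound 2 stands highest, with compound 1 nearest. Compound 3 `Cc1ccc(C(=O)Nc2c(C(O)(C(F)(F)F)C(F)(F)F)ccc3ccccc23)cc1` is still to be measured in this assay. It differs from compound 2 by methyl in place of iodo on an aromatic carbon. For the measured compounds named here, no measured step bears directly on this exchange: the single known step swaps ethyl for 4-iodophenyl, a different change at a different place, so it offers no direct guide. Because compound 2 gives 154 nM and the exchange counts only one heavy atom either way, compound 3 is expected to stay close, with a step of no change at the digits printed from compound 2 to compound 3 (within the scatter) not beyond the scatter. Compound 3 is therefore estimated at 154 nM, between 60 nM and 400 nM.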

Compound 3, half-maximal effective concentration: 76 nM
Estimate against measurement, compound 3: 2.0-fold (0.31 log units) above; the range from low to high includes it.
By their numbers in this assay, from the lowest: compound 1; then compound 3; then compound 2.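

In this assay, the group on the aromatic carbon of the amide aryl ring matters even when the heavy-atom count stays the same: methyl in place of iodo gives a 2.0-fold lower number from compound 2 to compound 3 (0.31 log units; beyond the scatter). The change recovers only part of the ground lost on moving from ethyl to an aryl group, since 4-methylphenyl in place of ethyl still gives a 5.1-fold higher number from compound 1 to compound 3 (0.70 log units; beyond the scatter), and both aryl amides, compound 2 and compound 3, keep higher numbers than compound 1. Nothing available accounts for the direction or size of either step.

From the compounds shown here alone, whether chloro, methoxy, an amine or a carboxylic acid on that same aromatic carbon would fall near methyl or near iodo remains open. For the compounds shown here, compound 1 has the lowest number so far. Going by these compounds, it also remains open whether any aryl group on the carbonyl carbon can match it.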